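Acetyl in Place of 1-Methylethenyl at Alpha-2C

The compounds below may be only part of what the source reports. "The series", "measured", "known", "first", "only" and "open" are said of these compounds alone.

Measured so far:
Compound 1 `CCOc1ccccc1OC(C)C1=NCCN1`: 0.45
Compound 2 `CC(Oc1ccccc1OC1CC1)C1=NCCN1`: 0.7
Compound 3 `C=C(C)c1ccccc1OC(C)C1=NCCN1`: 0.71

In an assay on CHO cells with Alpha-2C adrenergic receptor (Homo sapiens) as the target (a higher number here means a larger maximal response, a lower number a smaller maximal response), compound 3 gives 0.71, the highest of the three numbers. Its lead over compound 2 is small, a number 0.010 higher from compound 2 to compound 3 (within the scatter), and within the scatter, so the two cannot be ranked. Against compound 1 the gap is clear: a number 0.26 higher from compound 1 to compound 3 (beyond the scatter).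

Compound 4 `CC(=O)c1ccccc1OC(C)C1=NCCN1` has not yet been measured. It differs from compound 3 in one place: acetyl in place of 1-methylethenyl on an aromatic carbon

Going by the values given here, no measured step swaps in an acetyl group, so none bears directly on this change. The two steps that reach compound 3, a number 0.26 higher from compound 1 to compound 3 (beyond the scatter) and a number 0.010 higher from compound 2 to compound 3 (within the scatter), show that the group on this aromatic carbon can move the maximal response clearly or leave it unchanged. For compound 4 the expected step is a number 0.11 lower from compound 3 to compound 4 (beyond the scatter), a small loss with wide uncertainty. The estimated value for compound 4 in this assay is 0.6, between 0.35 and 0.85.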

Compound 4, intrinsic activity: the largest response reached, as a fraction of the reference agonist's: 0.65
For compound 4 the middle estimate is 0.050 below the measured one; low and high end bracket the measured number.
By their numbers in this assay, from the lowest: compound 1; then compounds 4, 2 and 3 (each within the scatter of the next).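

In this assay, this aromatic carbon tolerates a swap that keeps the same number of heavy atoms but adds a hydrogen-bond acceptor, since acetyl in place of 1-methylethenyl gives only a number 0.060 lower from compound 3 to compound 4 (within the scatter). Acetyl also matches cyclopropyloxy, with a number 0.050 lower from compound 2 to compound 4 (within the scatter), yet it stays clearly apart from ethoxy, with a number 0.20 higher from compound 1 to compound 4 (beyond the scatter), so among these four groups only ethoxy stands apart from the others. Nothing available explains why the three groups sit level or why ethoxy differs.

From the compounds shown here alone, it remains open whether an amine, a carboxylic acid or a longer chain on this aromatic carbon would keep the maximal response at this level. Every compound shown varies only the group on this carbon, so the effect of changes elsewhere on the shared core is also unknown.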